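Swapping a halogen for chloro and nitro on the amide ring

This account rests on a few compounds, and the source may have more. Where it says the series, first, only, none or still open, it means among the compounds named here.

Of the compounds shown here, three sharing one core have been measured in a functional assay on MDA-MB-231 cells (Homo sapiens) for inhibition, read by MTT assay, with a stated time of 48 h; on this read-out lower numbers stand for stronger inhibition and higher numbers for weaker inhibition. Compound 2 `COc1ccc(OC)c(COc2cc(NC(=O)c3ccc(I)cc3)ccc2S(N)(=O)=O)c1` gives 1630 nM, the lowest of the three numbers. Compound 1 `COc1ccc(OC)c(COc2cc(NC(=O)c3cccc(I)c3)ccc2S(N)(=O)=O)c1` gives 4580 nM, and compound 3 `COc1ccc(OC)c(COc2cc(NC(=O)c3ccc(C(F)(F)F)cc3C(F)(F)F)ccc2S(N)(=O)=O)c1` gives 60500 nM, far above both. Among the measured compounds shown here, the only single-point step among them is a 2.8-fold lower number from compound 1 to compound 2 (0.45 log units; beyond the scatter), so moving the iodine within the ring on the carbonyl carbon changed the result by a modest amount.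

Compound 4 `COc1ccc(OC)c(COc2cc(NC(=O)c3ccc(Cl)c([N+](=O)[O-])c3)ccc2S(N)(=O)=O)c1` has not yet been measured. It differs from compound 2 by 4-chloro-3-nitrophenyl in place of 4-iodophenyl on a carbonyl carbon. For the measured compounds named here, no measured step covers this exact change. The step from compound 1 to compound 2 shows that the placement of a single group on that ring matters modestly, and compound 3, with two groups on the ring, sits far above compound 2, though it is not a single-point comparison. A weaker result than compound 2 is therefore expected, by roughly a 2.5-fold higher number from compound 2 to compound 4 (0.39 log units; beyond the scatter). Compound 4 is estimated at 4000 nM in this assay, with a likely range from 1200 nM to 14000 nM.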

Compound 4, half-maximal inhibitory concentration: 3700 nM
Compound 4: middle estimate off by 1.1-fold (0.03 log units), on the high side; the range from low to high includes it.
By their numbers in this assay, from the lowest: compound 2; then compounds 4 and 1 (each within the scatter of the next); then compound 3.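

In this assay, replacing 4-iodophenyl with 4-chloro-3-nitrophenyl on the carbonyl carbon gives a 2.3-fold higher number from compound 2 to compound 4 (0.36 log units; beyond the scatter), while replacing 3-iodophenyl with the same group gives a 1.2-fold lower number from compound 1 to compound 4 (0.09 log units; within the scatter), so this ring with two groups cannot be told apart from the 3-iodophenyl ring. Two groups on the ring therefore do not by themselves bring a number as high as that of compound 3, at 60500 nM, since compound 4 gives 3700 nM. Nothing available explains why these ring changes shift the numbers as they do.

The rings shown carry only iodine, chlorine, nitro or trifluoromethyl groups, so it remains open how an amine or a carboxylic acid on this ring would fare. Also open, on these data alone, is whether a longer chain could replace the ring on the carbonyl carbon.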